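Isopentyl for 2-fluorophenyl: an expected permeability step

This account rests on a few compounds, and the source may have more. Where it says the series, first, only, none or still open, it means among the compounds named here.

Of the compounds shown here, three have been measured so far in an ADME assay on Caco-2 cells (Homo sapiens) for permeability, read by LC-MS, in the apical to basolateral direction, with a stated time of 60 min, at pH 6.5 (on this read-out lower numbers stand for lower permeability and higher numbers for higher permeability), and they do not differ in one place only. Compound 1 (`CC(C)(C)[C@@H](O)C(=O)N1CCS[C@H]1C(=O)NCc1cc(Cl)ccc1-n1cnnn1`) gives 5.2 10^-6 cm/s and compound 3 (`O=C(NCc1cc(Cl)ccc1-n1cnnn1)[C@@H]1C[C@@H]2C[C@@H]2N1C(=O)[C@H](O)C1CCCCC1`) gives 16 10^-6 cm/s while compound 2 (`O=C(NCc1cc(Cl)ccc1-n1cnnn1)[C@@H]1CC=NN1C(=O)[C@H](O)c1ccccc1F`) gives 8.9 10^-6 cm/s and so stands within the scatter of both others.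

Compound 4 (`CC(C)CC[C@@H](O)C(=O)N1N=CC[C@H]1C(=O)NCc1cc(Cl)ccc1-n1cnnn1`) has not yet been measured. The change from compound 2 is isopentyl in place of 2-fluorophenyl on a saturated chain carbon bound to a carbonyl carbon and an oxygen on a saturated carbon and it puts isopentyl in place of 2-fluorophenyl on a saturated chain carbon bound to a carbonyl carbon and an oxygen on a saturated carbon.

Among the measured compounds shown here, no measured pair shows this change directly. Neither of the other two compounds carries 2-fluorophenyl, yet compound 1 at 5.2 10^-6 cm/s and compound 3 at 16 10^-6 cm/s both lie within the scatter of compound 2. No shift beyond the scatter is therefore expected, in either direction. The expected size of the step is a 1.1-fold higher number from compound 2 to compound 4 (0.05 log units; within the scatter) and this estimate stays within the scatter. In this assay the estimate for compound 4 is 10 10^-6 cm/s (expected range 4.5 10^-6 cm/s to 22 10^-6 cm/s).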

Compound 4, apparent permeability: 29 10^-6 cm/s
For compound 4 the middle estimate is 2.9-fold (0.46 log units) below the measured one, and the stated range ends below it.
By their numbers in this assay, from the lowest: compounds 1, 2, 3 and 4 (each within the scatter of the next, the first and the last beyond it).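

In this assay, isopentyl in place of 2-fluorophenyl on a saturated chain carbon bound to a carbonyl carbon and an oxygen on a saturated carbon gives a 3.3-fold higher number from compound 2 to compound 4 (0.51 log units; beyond the scatter) as the only step shown that differs in one place. This position therefore does not leave the read-out unchanged: with the rest of compound 2 held fixed, replacing a group that carries a six-membered aromatic ring with one that has no ring moves the number beyond the scatter. No data at hand bear on what lies behind this step.

A single pair cannot separate the loss of the ring from the gain of the chain. Going by these compounds, how an amine or a longer chain would read at this position remains open, as does whether the same exchange would give a step of similar size on the core of compound 1 or compound 3.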